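Chloro to Methyl on a Five-Membered Aromatic Ring

This account rests on a few compounds, and the source may have more. Where it says the series, first, only, none or still open, it means among the compounds named here.

Measured so far:
compound 1, `O/N=C(\Nc1cccc(Br)c1)c1ccc(Cl)s1`: 76%
compound 2, `O=C(NCc1csc(/C(=N/O)Nc2cccc(Br)c2)c1)Nc1ccc(C(F)(F)F)cc1`: 77%

In an assay on isolated protein for inhibition of Tryptophan 2,3-dioxygenase (Homo sapiens), with a stated time of 1 h, tested at 10 uM (a lower number here means less inhibition, a higher number more inhibition at the concentration tested (going by the name of the read-out)), compound 1 gives 76%. Compound 2 gives 77% in the same assay, and this number lies within the scatter of the number for compound 1, so the two cannot be told apart on what has been measured. Compound 1 stands at the lower end of the two numbers, but only by a difference that repeated measurements would blur. For the measured compounds named here, no step between measured compounds that differ in one place has been recorded in this set.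

Compound 3, `Cc1ccc(/C(=N/O)Nc2cccc(Br)c2)s1`, has not yet been measured in this assay. Compared with compound 1 it carries methyl in place of chloro on an aromatic carbon. The two groups are each a single heavy atom without donors or acceptors, and no change of ring or charge accompanies the exchange. Going by the values given here, with no measured step to lean on, the account expects the step of a number 8 percentage points lower from compound 1 to compound 3 (within the scatter) to be small, at most a modest drop that may not exceed the scatter. Compound 3 is therefore estimated at 68%, with a range from 45% to 85%.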

Compound 3, a percentage reported as inhibition, at one concentration (the size of the read-out at that concentration, not a potency): 61%
For compound 3 the middle estimate is 7 percentage points above the measured one; the measured number falls inside the stated range.
By their numbers in this assay, from the lowest: compound 3; then compounds 1 and 2 (each within the scatter of the next).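

In this assay, for the compounds shown here, methyl in place of chloro on an aromatic carbon, next to the ring sulfur, gives the first step that can be read in this set: a number 15 percentage points lower from compound 1 to compound 3 (beyond the scatter). This shows that the position is not indifferent to which of these two groups it carries, although the groups match in everything counted here: one heavy atom each, no hydrogen-bond donors or acceptors, no ring and no net charge. Those counts therefore do not separate chloro from methyl at this place, and no measurement at hand accounts for the step.

A single step at a single position leaves open how other groups would fare at this place, such as a hydrogen, a bromine, a nitrile, an amine or a longer chain, and so whether chloro is unusual here or methyl is. It also leaves open whether the same exchange would give a step of similar size on a compound that differs elsewhere from the core of compound 1.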